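A Chloro Step at the Limit of a Cell Assay

The source may hold more compounds than are shown below. What is called first, only, known or untested is meant among the compounds shown, and "the series" means these compounds.

In an ADME assay on RAW264.7 cells (Mus musculus) for cytotoxicity, read by MTT assay, with a stated time of 24 h, in the presence of a further agent that is not named here (a higher number here means a weaker inhibitor, a lower number a stronger inhibitor), compound 1 (`CCC(C)Oc1ccc(C(O)C2OC(=O)c3c(OC)cc(OC)cc32)cc1`) gives > 40000 nM, which is a limit of the assay and not a number. Compound 2 (`COc1cc(OC)c2c(c1)C(C(O)c1ccc(OCc3ccccc3)cc1)OC2=O`) gives > 40000 nM, which is also a limit. Compound 2 therefore has no exact place on the scale, and the only result to compare it with is the limit of compound 1.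

Compound 3 (`COc1cc(OC)c2c(c1)C(C(O)c1ccc(OCc3ccc(Cl)cc3)cc1)OC2=O`) keeps the core of compound 2 and differs in one place: chloro in place of hydrogen on an aromatic carbon. In words, benzyl becomes 4-chlorobenzyl, with chloro in place of hydrogen on an aromatic carbon.

Within the data shown here, the one measured step that bears on this change is a step that the two limits leave unreadable from compound 1 to compound 2, where benzyl replaces sec-butyl on an oxygen on an aromatic ring. It offers no size to carry over. All the evidence so far is the limit of > 40000 nM in this assay, at which 2 of the 2 values shown sit. On this basis, no step beyond the scatter is expected in this assay, and no direction can be argued. The expected step is a step that the limit leaves unreadable from compound 2 to compound 3. The estimate for compound 3 is 45000 nM, with an expected range from 20000 nM to 90000 nM.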

Compound 3, half-maximal inhibitory concentration: > 40000 nM
Compound 3: a limit, no number; the forecaster's own chance of this, stated with the estimate: 80%; the middle value does not contradict the limit.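

In this assay compound 3 gives > 40000 nM, which is a limit of the assay and not a number. No step between compound 1, compound 2 and compound 3 can be read, so the chloro change has no size here: the limit of > 40000 nM in this assay, at which 3 of the 3 values shown sit.

The compounds shown leave open what exact half-maximal inhibitory concentration, if any, each of them has in this assay.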